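The source may hold more compounds than are shown below. What is called first, only, known or untested is meant among the compounds shown, and "the series" means these compounds.

Compound 3 `COc1nc(-c2ccc(F)cc2)ccc1[C@@H](c1ccccc1)[C@@](O)(CCN(C)C)c1cccc2ccccc12` belongs to a set of three close relatives that share one core. In a toxicity assay on Vero cells (Chlorocebus sabaeus) for cytotoxicity (a higher number here means that more compound is tolerated, a lower number that less compound is tolerated), compound 3 gives > 50 ug/mL, which is a limit of the assay rather than a number. Compound 1 `COc1nc(-c2ccccc2F)ccc1[C@@H](c1ccccc1)[C@@](O)(CCN(C)C)c1cccc2ccccc12` likewise gives > 50 ug/mL in this assay, again a limit. Compound 2 `COc1nc(-c2ccc(Br)cc2)ccc1[C@@H](c1ccccc1)[C@@](O)(CCN(C)C)c1cccc2ccccc12` gives > 50 ug/mL in this assay, also a limit. Compound 3 thus stands together with the other two at the limit of > 50 ug/mL in this assay, at which 3 of the 3 values shown sit.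

The step to compound 4 `COc1nc(-c2ccc(Cl)c(F)c2)ccc1[C@@H](c1ccccc1)[C@@](O)(CCN(C)C)c1cccc2ccccc12` is 4-chloro-3-fluorophenyl in place of 4-fluorophenyl on an aromatic carbon. Within the data shown here, three measured steps bear on it: a step that the two limits leave unreadable from compound 1 to compound 3, a step that the two limits leave unreadable from compound 1 to compound 2 and a step that the two limits leave unreadable from compound 2 to compound 3. None of them can be sized because the limit of > 50 ug/mL in this assay, at which 3 of the 3 values shown sit, caps every value in the set. The evidence therefore yields no readable step in this assay, and no change beyond the scatter is expected, a step that the limit leaves unreadable from compound 3 to compound 4. Compound 4 is accordingly expected at 60 ug/mL, with a range from 30 ug/mL to 120 ug/mL, and most likely it will again be reported only as a limit.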

Compound 4, half-maximal cytotoxic concentration: > 50 ug/mL
Compound 4: only a limit was reported (the forecaster's own chance of this, stated with the estimate: 75%); the middle value is on the limit's open side.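

In this assay compound 4 gives > 50 ug/mL, which is a limit. Its steps to compound 1, compound 2 and compound 3 cannot be read: the limit of > 50 ug/mL in this assay, at which 4 of the 4 values shown sit. The compounds shown leave open at what concentration any of the four becomes toxic in this assay, and whether the exchanged groups differ at all.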